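A few compounds are considered here, and "the series" means these few. Any claim that something is new, unique, unknown or untested is made for them only; others in the source may bear on it.

Measured so far in an ADME assay on RAW264.7 cells (Mus musculus) for cytotoxicity, read by MTT assay, with a stated time of 72 h, tested at 50 uM; on this read-out lower numbers stand for a weaker effect and higher numbers for a stronger effect at the one concentration tested:

compound 1, `O=C(Cn1c(=O)oc2cc([N+](=O)[O-])ccc21)Nc1ccccn1`, 38.6%
compound 2, `O=C(Cn1c(=O)oc2cc([N+](=O)[O-])ccc21)Nc1ccccc1`, 18%
compound 3, `O=C(Cn1c(=O)oc2ccccc21)Nc1ccccc1`, 35.1%

Compound 1 and compound 2 share one core and differ only by pyridin-2-yl in place of phenyl on an amide-type nitrogen; that change gives a number 20.6 percentage points higher from compound 2 to compound 1 (beyond the scatter). Compound 3 differs from compound 2 in the core itself, by hydrogen in place of nitro on an aromatic carbon, and that change gives a number 17.1 percentage points higher from compound 2 to compound 3 (beyond the scatter). Compound 3 and compound 1 lie within the scatter of each other in this assay, so no order between them can be read.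

Compound 4, `O=C(Cn1c(=O)oc2ccccc21)Nc1ccccn1`, has not yet been measured. It differs from compound 3 by pyridin-2-yl in place of phenyl on an amide-type nitrogen, on a place that reads word for word as the one in the change from compound 2 to compound 1, so it is the same change, seen here for the second time among these compounds. From compound 3 to compound 4 a step of a number 14.9 percentage points higher from compound 3 to compound 4 (beyond the scatter) is expected, somewhat smaller than the earlier step, because a number 20.6 percentage points higher from compound 2 to compound 1 (beyond the scatter) was seen on the other core and compound 3 already stands at 35.1%. For compound 4 the estimated value is 50%, between 36% and 64%.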

Compound 4, a percentage reported as inhibition, at one concentration (the size of the read-out at that concentration, not a potency): 20.2%
Compound 4: the middle estimate sits 29.8 percentage points above what was measured, and the stated range ends above it.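

In this assay, pyridin-2-yl in place of phenyl on an amide-type nitrogen gives a number 14.9 percentage points lower from compound 3 to compound 4 (beyond the scatter), so this change does not carry over from the core of compound 2 to the core of compound 3, in direction or in size: the same change on two cores in this assay, a number 20.6 percentage points higher (beyond the scatter) from compound 2 to compound 1 and a number 14.9 percentage points lower (beyond the scatter) from compound 3 to compound 4, 35.5 percentage points apart, beyond the scatter of two such steps Read from the other side of the same four compounds, hydrogen in place of nitro on an aromatic carbon gives a number 18.4 percentage points lower from compound 1 to compound 4 (beyond the scatter), which also reverses the direction seen with the phenyl amides: the same change on two cores in this assay, a number 17.1 percentage points higher (beyond the scatter) from compound 2 to compound 3 and a number 18.4 percentage points lower (beyond the scatter) from compound 1 to compound 4, 35.5 percentage points apart, beyond the scatter of two such steps The effect of each change thus depends on the other within this set, but the set is a single group of four compounds, and it does not show why the read-out moves or whether the reversal is general.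

The compounds shown leave open whether an amine or a nitrile in place of nitro on that aromatic carbon would also reverse the step. They also leave open how a phenyl or pyridin-2-yl bearing a carboxylic acid would behave on the amide-type nitrogen.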